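Notes on the aryl swap from compound 2 to compound 3

The source may hold more compounds than are shown below. What is called first, only, known or untested is meant among the compounds shown, and "the series" means these compounds.

Compound 1 `N#CC1=C(N)Oc2c(c3nc4ccccc4nc3c3ccccc23)C12C(=O)N(Cc1cnnn1-c1ccc(Br)cc1)c1ccccc12` is the reference of this pair. In a functional assay on MCF7 cells (Homo sapiens) for antiproliferative activity, read by MTT assay, with a stated time of 48 h (on this read-out higher numbers stand for weaker inhibition and lower numbers for stronger inhibition), compound 1 gives 36600 nM. Compound 2 `N#CC1=C(N)Oc2c(c3nc4ccccc4nc3c3ccccc23)C12C(=O)N(Cc1cnnn1-c1ccccc1Br)c1ccccc12` carries a 2-bromophenyl in place of the 4-bromophenyl on the aromatic nitrogen. In this assay compound 2 reaches only the limit of the assay, > 50000 nM, so no number is known for it. Compound 2 thus stands at the limit of > 50000 nM in this assay, at which 1 of the 2 values shown sits. The step of an at least 1.3-fold higher number from compound 1 to compound 2 (0.13 log units; that floor lies within the scatter) is bounded on one side only. Compound 3 `COc1ccc(-n2nncc2CN2C(=O)C3(C(C#N)=C(N)Oc4c3c3nc5ccccc5nc3c3ccccc43)c3ccccc32)cc1` is not yet measured; it differs from compound 2 by 4-methoxyphenyl in place of 2-bromophenyl on an aromatic nitrogen. No measured step exchanges bromine for methoxy; the only step shown, an at least 1.3-fold higher number from compound 1 to compound 2 (0.13 log units; that floor lies within the scatter), swaps one bromophenyl for another and is itself bounded at the limit. A number near the limit is therefore expected for compound 3, with the step of an at least 1.1-fold lower number from compound 2 to compound 3 (0.04 log units; that floor lies within the scatter) expected to stay within the scatter. The estimate for compound 3 in this assay is 45000 nM, ranging from 15000 nM to 120000 nM.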

Compound 3, half-maximal inhibitory concentration: > 50000 nM
Compound 3: no number, only a limit (the forecaster's own chance of this, stated with the estimate: 50%); at least 1.1-fold (0.04 log units) between middle value and limit.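

Compound 3 gives a limit and not a number in this assay, so a 4-methoxyphenyl, with a hydrogen-bond acceptor that the 2-bromophenyl lacks, does not yield a readable value at this position on the aromatic nitrogen. Against the reference, methoxy in place of bromo on an aromatic carbon reads as an at least 1.3-fold higher number from compound 1 to compound 3 (0.13 log units; that floor lies within the scatter), so this change cannot be separated from compound 1, and the step between the two limited compounds cannot be read. Most of the series now sits at the ceiling of this read-out: the limit of > 50000 nM in this assay, at which 2 of the 3 values shown sit.

Among these compounds, how far the values at this position can move remains open, since the only number here is that of compound 1. A phenyl bearing an amine or a carboxylic acid, or a longer alkyl chain in place of the aryl group on this nitrogen, could test that.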